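The source may hold more compounds than are shown below. What is called first, only, known or untested is meant among the compounds shown, and "the series" means these compounds.

Compound 3 `CC(C)(C)Cc1cnc(CCc2ccc(-c3ccccc3C(=O)O)cc2)[nH]1` is the starting point here. Going by the values given here, in an in vitro functional assay on cells for agonist activity at Bombesin receptor subtype-3 (Mus musculus), read by luminescence and calcium flux (on this read-out lower numbers stand for an effect already at smaller amounts and higher numbers for an effect only at larger amounts of compound), compound 3 gives 6.3 nM, the second highest of the three numbers measured so far; its nearest neighbour is compound 2 `CC(C)(C)CCc1cnc(CCc2ccc(-c3ccccc3C(=O)O)cc2)[nH]1`, which in this assay gives 6.2 nM, and the furthest is compound 1 `O=C(O)c1ccccc1-c1ccc(CCc2ncc(CC3CCC3)[nH]2)cc1`, which gives 7.1 nM. All three lie within the scatter of one another, as the steps show: a 1.1-fold lower number from compound 1 to compound 2 (0.06 log units; within the scatter), a 1.1-fold lower number from compound 1 to compound 3 (0.05 log units; within the scatter) and a 1.0-fold higher number from compound 2 to compound 3 (0.01 log units; within the scatter). Compound 4 `N#Cc1cccc(Cc2cnc(CCc3ccc(-c4ccccc4C(=O)O)cc3)[nH]2)c1` differs from compound 3 in one place: 3-cyanophenyl in place of tert-butyl on a saturated chain carbon bound to an aromatic carbon. The measured steps bear on this only at a distance, since they exchange cyclobutyl, neopentyl and tert-butyl at the same place and none of them moves beyond the scatter. Nothing measured speaks to a six-membered aromatic ring with a nitrile entering there, so the expectation rests on the quiet behaviour of this position alone, with a wide range. Compound 4 is therefore expected to give about 8 nM, between 2.5 nM and 30 nM. That estimate means a step of a 1.3-fold higher number from compound 3 to compound 4 (0.10 log units; within the scatter) is expected, essentially none beyond the scatter.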

Compound 4, half-maximal effective concentration: 20 nM
The estimate for compound 4 lay 2.5-fold (0.40 log units) below the measured number, and the stated range covers the measured number.
By their numbers in this assay, from the lowest: compounds 2, 3 and 1 (each within the scatter of the next); then compound 4.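

Across cyclobutyl, neopentyl and tert-butyl this position gave no step beyond the scatter, but in this assay the entry of 3-cyanophenyl shows that it can respond: there is a 3.2-fold higher number from compound 3 to compound 4 (0.50 log units; beyond the scatter) and a 3.2-fold higher number from compound 2 to compound 4 (0.51 log units; beyond the scatter) as well as a 2.8-fold higher number from compound 1 to compound 4 (0.45 log units; beyond the scatter) in the same direction. All three steps are modest, so a six-membered aromatic ring carrying a nitrile is accepted on this saturated chain carbon, though with a higher number than any of the three smaller groups. Nothing available bears on what lies behind this step.

The ring and the nitrile enter together, and the compounds shown do not separate their shares in the step. From the compounds shown here alone, how a plain phenyl, a cyclohexyl or a chain ending in an amine would read at this place also remains open.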